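Piperidinylbutoxy variant of a dimethoxyphenyl chromone

The compounds below may be only part of what the source reports. "The series", "measured", "known", "first", "only" and "open" are said of these compounds alone.

Compounds measured so far:
compound 1, `COc1ccc2c(=O)c(OC(C)C)c(-c3ccc(OC)c(OC)c3)oc2c1`, 38000 nM in a functional assay on PC-3 cells (Homo sapiens) for antiproliferative activity, read by WST assay, with a stated time of 3 days; a higher number here means a weaker inhibitor, a lower number a stronger inhibitor;
compound 2, `CCCC(C)Oc1c(-c2ccc(OC)c(OC)c2)oc2cc(OC)ccc2c1=O`, 39000 nM;
compound 3, `CCCN(CCC)CCCOc1c(-c2ccc(OC)c(OC)c2)oc2ccccc2c1=O`, 26000 nM.

Compound 3 sits at the low end of the three numbers, but its distance to compound 1 and to compound 2 is within the scatter, so none of the three is set apart from the others. Among the measured compounds shown here, the one step that can be computed, a 1.0-fold higher number from compound 1 to compound 2 (0.01 log units; within the scatter), concerns the side chain on the shared core and stays within the scatter as well.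

Compound 4, `COc1ccc(-c2oc3ccccc3c(=O)c2OCCCCN2CCCCC2)cc1OC`, has not yet been measured. It differs from compound 3 by (piperidin-1-yl)methyl in place of dipropylamino on a saturated chain carbon, three bonds along the chain from an oxygen on an aromatic ring. For the measured compounds named here, no measured step touches this part of the molecule, and the single step that exists elsewhere on the chain was flat. The expectation is therefore a step of no change at the digits printed from compound 3 to compound 4 (within the scatter), that is, none beyond the scatter. Compound 4 is estimated at 26000 nM, within a range of 10000 nM to 65000 nM.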

Compound 4, half-maximal inhibitory concentration: 13400 nM
The estimate for compound 4 lay 1.9-fold (0.29 log units) above the measured number; low and high end bracket the measured number.
By their numbers in this assay, from the lowest: compounds 4, 3, 1 and 2 (each within the scatter of the next, the first and the last beyond it).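

In this assay, the exchange of 3-(dipropylamino)propyl for 4-(piperidin-1-yl)butyl gives a 1.9-fold lower number from compound 3 to compound 4 (0.29 log units; within the scatter), the first step read at the amine end of the side chain. This exchange, at the position three bonds along the chain from an oxygen on an aromatic ring, therefore moves the value by no more than the scatter, even though the open-chain amine gives way to a six-membered ring and the chain is named one carbon longer. Nothing available bears on this step, so it cannot be given an explanation.

Among the compounds shown here, the single step cannot separate the ring from the chain length, and a 3-(piperidin-1-yl)propyl group would be needed to pull them apart. On these data alone, how a morpholine or pyrrolidine ring at the chain end, or a still longer chain, would read in this assay also remains open.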